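A few compounds are considered here, and "the series" means these few. Any claim that something is new, unique, unknown or untested is made for them only; others in the source may bear on it.

In a functional assay on HUVEC cells (Homo sapiens) for inhibition (a higher number here means a weaker inhibitor, a lower number a stronger inhibitor), three compounds with a shared core have been measured. Compound 1 (`CC(=O)c1ccc(NC(=O)Nc2ccc(N(C)c3ccnc(Nc4cccc(CS(C)(=O)=O)c4)n3)cc2)cc1`) gives 2 nM, compound 2 (`CN(c1ccc(NC(=O)Nc2c(Cl)cccc2Cl)cc1)c1ccnc(Nc2cccc(CS(C)(=O)=O)c2)n1`) gives 29 nM, and compound 3 (`CCNC(=O)Nc1ccc(N(C)c2ccnc(Nc3cccc(CS(C)(=O)=O)c3)n2)cc1`) gives 3 nM. Compound 3 therefore stands level with compound 1, within the scatter, and well apart from compound 2.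

Compound 4 (`CN(c1ccc(NC(=O)NC2CCCC2)cc1)c1ccnc(Nc2cccc(CS(C)(=O)=O)c2)n1`) has cyclopentyl in place of ethyl on an amide-type nitrogen. All three measured steps change this same substituent, although none tests cyclopentyl directly. The step of a 1.5-fold higher number from compound 1 to compound 3 (0.18 log units; within the scatter) lies within the scatter, while a 15-fold higher number from compound 1 to compound 2 (1.16 log units; beyond the scatter) is large and a 9.7-fold lower number from compound 2 to compound 3 (0.99 log units; beyond the scatter) is modest.

Ethyl and 4-acetylphenyl thus give values within the scatter of each other, and only 2,6-dichlorophenyl stands apart. With the step of a 1.5-fold higher number from compound 1 to compound 3 (0.18 log units; within the scatter) as the closest guide, no step beyond the scatter is expected in this assay, though a slightly higher number is thought likelier than a lower one. The expected step is a 1.7-fold higher number from compound 3 to compound 4 (0.22 log units; within the scatter). For compound 4 the estimated value is 5 nM, with an expected range of 1.5 nM to 20 nM.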

Compound 4, half-maximal inhibitory concentration: 1 nM
Beside the measured number, compound 4's estimate is 5.0-fold (0.70 log units) above it; measured number below the stated range.
By their numbers in this assay, from the lowest: compounds 4, 1 and 3 (each within the scatter of the next, the first and the last beyond it); then compound 2.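

In this assay, among the compounds shown here, the change from ethyl to cyclopentyl on the amide-type nitrogen gives a 3.0-fold lower number from compound 3 to compound 4 (0.48 log units; beyond the scatter), so this position still responds between two non-aromatic groups, a difference the earlier compounds did not show. For the compounds shown here, the other two steps place cyclopentyl with 4-acetylphenyl, with a 2.0-fold lower number from compound 1 to compound 4 (0.30 log units; within the scatter), and far from 2,6-dichlorophenyl, with a 29-fold lower number from compound 2 to compound 4 (1.46 log units; beyond the scatter), which leaves 2,6-dichlorophenyl as the one group of the four well apart from the others. No supporting data are available to explain these differences.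

Ethyl and cyclopentyl differ in both carbon count and ring, so it remains open which of the two goes with this step; a straight pentyl chain on the same nitrogen would separate them. As far as these compounds go, how a chain ending in an amine or a carboxylic acid would behave at this position also remains open.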